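A few compounds are considered here, and "the series" means these few. Any claim that something is new, unique, unknown or untested is made for them only; others in the source may bear on it.

Measured compounds:
- compound 1, `O=C1NCCN1c1ccc(S(=O)(=O)Nc2cccc(Br)c2)cc1`, in a functional assay on HT-29 cells (Homo sapiens) for antiproliferative activity, read by sulforhodamine B assay, with a stated time of 48 h (a higher number here means a weaker inhibitor, a lower number a stronger inhibitor), gives 77 nM
- compound 2, `Cc1ccccc1NS(=O)(=O)c1ccc(N2CCNC2=O)cc1`, in this assay gives 200 nM
- compound 3, `COc1ccccc1NS(=O)(=O)c1ccc(N2CCNC2=O)cc1`, in this assay gives 550 nM

Compound 3 stands at the highest of the three numbers: the gap is a 7.1-fold higher number from compound 1 to compound 3 (0.85 log units; beyond the scatter) and a 2.8-fold higher number from compound 2 to compound 3 (0.44 log units; beyond the scatter). The unmeasured compound 4, `Cc1ccc(NS(=O)(=O)c2ccc(N3CCNC3=O)cc2)c(C)c1`, differs from compound 3 in one place: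

2,4-dimethylphenyl in place of 2-methoxyphenyl on a sulfonamide nitrogen

Within the data shown here, two measured steps bear on this change. The step of a 2.8-fold higher number from compound 2 to compound 3 (0.44 log units; beyond the scatter) shows that methoxy in place of methyl on the aromatic carbon raises the number; compound 4 reverses that exchange, so the methyl part of the change should pull the number back toward that of compound 2. The step of a 2.6-fold higher number from compound 1 to compound 2 (0.41 log units; beyond the scatter) sets where a 2-methylphenyl stands against the 3-bromophenyl of compound 1. Nothing measured here tells what the second methyl of the 2,4-dimethylphenyl adds. The writer therefore expects a modest downward step, a 2.5-fold lower number from compound 3 to compound 4 (0.40 log units; beyond the scatter), and estimates that compound 4 in this assay gives 220 nM, most likely between 80 nM and 600 nM.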

Compound 4, half-maximal inhibitory concentration: 180 nM
Compound 4: the middle estimate sits 1.2-fold (0.09 log units) above what was measured; low and high end bracket the measured number.
By their numbers in this assay, from the lowest: compound 1; then compounds 4 and 2 (each within the scatter of the next); then compound 3.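

In this assay, among these compounds, the extra methyl of the 2,4-dimethylphenyl group on the sulfonamide nitrogen makes no difference that can be told from the scatter against the 2-methylphenyl group (a 1.1-fold lower number from compound 2 to compound 4 (0.05 log units; within the scatter)), which settles what the earlier compounds could not show about this methyl. Taking out the 2-methoxyphenyl group for the 2,4-dimethylphenyl group gives a step beyond the scatter (a 3.1-fold lower number from compound 3 to compound 4 (0.49 log units; beyond the scatter)), in line with the earlier methyl and methoxy comparison, yet the 3-bromophenyl group keeps the lowest number of the four (a 2.3-fold higher number from compound 1 to compound 4 (0.37 log units; beyond the scatter)). No measurement given here offers a reason for any of these steps.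

The compounds shown leave open how an amine, a carboxylic acid or a longer chain such as propyl on this aromatic ring would read in this assay. They also leave open whether chlorine in place of bromine would hold the number of compound 1 (77 nM).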